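Swapping methyl for fluoro on a cytotoxic triazolothiadiazine

This account rests on a few compounds, and the source may have more. Where it says the series, first, only, none or still open, it means among the compounds named here.

Compound 1 `COc1cc(-c2nnc3n2NC(c2ccco2)C(C(=O)c2ccc(F)cc2)S3)cc(OC)c1OC` carries a furan ring and a fluorophenyl carbonyl on the shared core. In a functional assay on MCF7 cells (Homo sapiens) for cytotoxicity, read by MTT assay, with a stated time of 48 h (on this read-out higher numbers stand for weaker inhibition and lower numbers for stronger inhibition), compound 1 gives only a limit, > 100000 nM, not a number. Compound 2 `COc1cc(-c2nnc3n2NC(c2cccs2)C(C(=O)c2ccc(C)cc2)S3)cc(OC)c1OC` has a thiophene ring in place of the furan and a methylphenyl carbonyl in place of the fluorophenyl one, and in this assay compound 2 gives 28400 nM. This is the only proper number shown; the other value is a limit, which the limit of > 100000 nM in this assay, at which 1 of the 2 values shown sits, records. Compound 3 `COc1cc(-c2nnc3n2NC(c2cccs2)C(C(=O)c2ccc(F)cc2)S3)cc(OC)c1OC` is not yet measured. It differs from compound 2 by fluoro in place of methyl on an aromatic carbon, in words: fluoro in place of methyl on an aromatic carbon. Among the measured compounds shown here, no single step between measured compounds exists for this change, so the size of its effect in this assay is open. The step from compound 2 to compound 3 is expected to weaken inhibition modestly, a 1.9-fold higher number from compound 2 to compound 3 (0.29 log units; within the scatter), with a real chance that only a limit is returned. Compound 3 is therefore estimated at 55000 nM, with a range from 18000 nM to 150000 nM.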

Compound 3, half-maximal inhibitory concentration: 43700 nM
Estimate against measurement, compound 3: 1.3-fold (0.10 log units) above; the range from low to high includes it.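

In this assay, the change from 4-methylphenyl to 4-fluorophenyl can now be read on its own, with the thiophen-2-yl group held fixed, and it gives a 1.5-fold higher number from compound 2 to compound 3 (0.19 log units; within the scatter). Among the compounds shown here, on this aromatic carbon, para to a large group, fluoro and methyl therefore cannot be told apart in this read-out, which the two-place difference between the earlier compounds could not show. With the 4-fluorophenyl group held fixed, thiophen-2-yl in place of furan-2-yl on a saturated ring carbon gives an at least 2.2-fold lower number from compound 1 to compound 3 (0.35 log units; beyond the scatter), so among these compounds the clear difference lies at the ring on the saturated carbon, although the size of that step has no upper end, as compound 1 gives only a limit and not a number: the limit of > 100000 nM in this assay, at which 1 of the 3 values shown sits.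

The compounds shown leave open whether a chloro, a methoxy or a carboxylic acid on that same aromatic carbon would move the number beyond the scatter. They also leave open whether a phenyl ring or a pyridine ring in place of the thiophen-2-yl group would strengthen inhibition further than thiophen-2-yl does.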